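Gem-dimethyl trimmed to methyl: compound 1 to compound 3

The source may report more compounds than this note shows. Statements on the series, on what has been measured and on what is new or still open speak of the compounds shown alone.

Measured so far:
compound 1, `CC(C)(CCSCCC(N)C(=O)O)CC(=O)O`: 100%
compound 2, `C[C@H](NCCSCCC(N)C(=O)O)C(=O)O`: 19.8%

In an assay for inhibition of betaine--homocysteine S-methyltransferase 1 (Homo sapiens), tested at 20 uM (a higher number here means more inhibition at the concentration tested (going by the name of the read-out), a lower number less inhibition), compound 1 gives 100%, the higher of the two numbers on hand. Compound 2 gives 19.8%, and the gap to compound 1 lies beyond the scatter. Compound 3, `CC(CCSCCC(N)C(=O)O)CC(=O)O`, is not yet measured; it differs from compound 1 by hydrogen in place of methyl on a saturated chain carbon bound to three saturated chain carbons. Going by the values given here, no measured pair covers this change, and compound 2 differs from both in other places, so there is no direct precedent. A modest loss is expected: the step of a number 15 percentage points lower from compound 1 to compound 3 (beyond the scatter) is the estimate. Compound 3 is expected to give 85%, with a range of 55% to 100%.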

Compound 3, a percentage reported as inhibition, at one concentration (the size of the read-out at that concentration, not a potency): 100%
Estimate against measurement, compound 3: 15 percentage points below, within the range that was stated.
By their numbers in this assay, from the lowest: compound 2; then compounds 1 and 3 (each within the scatter of the next).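

In this assay hydrogen in place of methyl on a saturated chain carbon bound to three saturated chain carbons gives no change at the digits printed from compound 1 to compound 3 (within the scatter) and so the methyl that leaves is not needed to hold the read-out at the concentration tested. The read-out is not a potency, so any difference between compound 1 and compound 3 at other concentrations cannot be read from it. No evidence bearing on this result is at hand.

Open, on these data alone, is whether the methyl remaining on this carbon can also be replaced by hydrogen, and how an ethyl or a hydroxyl group there would read out.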